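Seven-Membered Amine Ring Tested for Cell Toxicity

The source may hold more compounds than are shown below. What is called first, only, known or untested is meant among the compounds shown, and "the series" means these compounds.

In an ADME assay on MT4 cells (Homo sapiens) for cytotoxicity, read by MTT assay, with a stated time of 4 days (on this read-out higher numbers stand for lower toxicity in this test and lower numbers for higher toxicity in this test), compound 1 `CN(C)c1nc(Cc2c(F)cccc2F)cc(=O)[nH]1` reaches only a limit of the assay, reported as > 94000 nM. Compound 2 `CC1CCCN(c2nc(Cc3c(F)cccc3F)cc(=O)[nH]2)C1` also ends at a limit, given as > 78000 nM. Compound 3 `CC1CCN(c2nc(Cc3c(F)cccc3F)cc(=O)[nH]2)CC1` likewise ends at a limit, given as > 78000 nM. The steps a step that the two limits leave unreadable from compound 1 to compound 2 and a step that the two limits leave unreadable from compound 1 to compound 3 therefore cannot be sized, as the limit of > 78000 nM in this assay, at which 2 of the 3 values shown sit, and the limit of > 94000 nM in this assay, at which 1 of the 3 values shown sits, show. Compound 4 `O=c1cc(Cc2c(F)cccc2F)nc(N2CCCCCC2)[nH]1` has not been measured; it differs from compound 1 by azepan-1-yl in place of dimethylamino on an aromatic carbon. The related changes to 3-methylpiperidin-1-yl and 4-methylpiperidin-1-yl left no readable step, so no step beyond the scatter is expected here, and another limit is the likely outcome. The value expected for compound 4 is 100000 nM, with a range from 50000 nM to 200000 nM. This corresponds to an expected step that the limit leaves unreadable from compound 1 to compound 4.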

Compound 4, half-maximal cytotoxic concentration: > 78000 nM
Compound 4: a limit, no number; the forecaster's own chance of this, stated with the estimate: 85%; the middle value does not contradict the limit.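

Within the data shown here, compound 4 ends at a limit, as do compound 1, compound 2 and compound 3, so no step among them can be read in this assay: the limit of > 78000 nM in this assay, at which 3 of the 4 values shown sit. The compounds shown leave open at what concentration each would harm these cells, and whether the amine group changes that concentration.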